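The source may report more compounds than this note shows. Statements on the series, on what has been measured and on what is new or still open speak of the compounds shown alone.

Measured in a functional assay on MDA-MB-231 cells (Homo sapiens) for cytotoxicity, read by MTT assay, with a stated time of 72 h; a lower number here means a stronger inhibitor, a higher number a weaker inhibitor:
compound 1 `O=C1c2c[n+]([O-])c3ccccc3c2C(=O)c2c1c1ccccc1n2CCN1CCCC1` gives 630 nM
compound 2 `CCCCN1CCN(CCCCn2c3c(c4ccccc42)C(=O)c2c[n+]([O-])c4ccccc4c2C3=O)CC1` gives 900 nM
compound 3 `O=C1c2c[n+]([O-])c3ccccc3c2C(=O)c2c1c1ccccc1n2Cc1cn(C[C@@H](O)CO)nn1` gives 670 nM

Compound 3 stands within the scatter of both other compounds. Compound 4 `O=C1c2c[n+]([O-])c3ccccc3c2C(=O)c2c1c1ccccc1n2CCCN1CCC(O)CC1` is the next to be read, and the change is 2-(4-hydroxypiperidin-1-yl)ethyl in place of 1-(2,3-dihydroxypropyl)-1H-1,2,3-triazol-4-yl on a saturated chain carbon bound to an aromatic nitrogen, with 2-(4-hydroxypiperidin-1-yl)ethyl in place of 1-(2,3-dihydroxypropyl)-1H-1,2,3-triazol-4-yl on a saturated chain carbon bound to an aromatic nitrogen. Two measured side-chain exchanges on the shared core bear on this: a 1.1-fold higher number from compound 1 to compound 3 (0.03 log units; within the scatter) and a 1.4-fold higher number from compound 1 to compound 2 (0.15 log units; within the scatter), both within the scatter. No step beyond the scatter is therefore expected in this assay here. The expected step is a 1.0-fold higher number from compound 3 to compound 4 (0.02 log units; within the scatter) as estimated. For compound 4 the estimated value is 700 nM, with an expected range of 300 nM to 1600 nM.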

Compound 4, half-maximal inhibitory concentration: 280 nM
The estimate for compound 4 lay 2.5-fold (0.40 log units) above the measured number, outside the stated range (below it).
By their numbers in this assay, from the lowest: compound 4; then compounds 1, 3 and 2 (each within the scatter of the next).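

In this assay, 3-(4-hydroxypiperidin-1-yl)propyl is the only side chain shown that moves the number beyond the scatter on the shared core (a 2.4-fold lower number from compound 3 to compound 4 (0.38 log units; beyond the scatter); a 2.3-fold lower number from compound 1 to compound 4 (0.35 log units; beyond the scatter); a 3.2-fold lower number from compound 2 to compound 4 (0.51 log units; beyond the scatter)). The earlier exchanges stayed within the scatter, whereas this one shows that the position, on a saturated chain carbon bound to an aromatic nitrogen, can respond to the side chain, if modestly. Nothing measured here explains the step.

Compound 4 leaves open whether the step follows the ring hydroxyl or the propyl chain. A plain piperidine or a morpholine on the same propyl chain would separate these.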